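Swapping tert-butyl for cyclohexyl at the amide chain end

The source may hold more compounds than are shown below. What is called first, only, known or untested is meant among the compounds shown, and "the series" means these compounds.

Compound 3 `Cc1nc2cc(C(=O)NCCC(C)(C)C)nn2c(-c2cc(F)c3c(c2C)CCCO3)c1[C@H](OC(C)(C)C)C(=O)O` carries a neopentyl group on a saturated chain carbon bound to an amide-type nitrogen. In an ADME assay on MT2 cells (Homo sapiens) for cytotoxicity (on this read-out lower numbers stand for higher toxicity in this test and higher numbers for lower toxicity in this test), compound 3 gives > 40000 nM, which is a limit of the assay rather than a measured number. Compound 1 `Cc1nc2cc(C(=O)NCc3ccc(F)c(C4CC4)c3)nn2c(-c2cc(F)c3c(c2C)CCCO3)c1[C@H](OC(C)(C)C)C(=O)O` also gives only a limit, > 40000 nM. Compound 2 `Cc1nc2cc(C(=O)NCc3ccc(F)cc3O)nn2c(-c2cc(F)c3c(c2C)CCCO3)c1[C@H](OC(C)(C)C)C(=O)O` likewise gives a limit, > 40000 nM. The change to compound 4 `Cc1nc2cc(C(=O)NCCC3CCCCC3)nn2c(-c2cc(F)c3c(c2C)CCCO3)c1[C@H](OC(C)(C)C)C(=O)O` is cyclohexyl in place of tert-butyl on a saturated chain carbon, two bonds along the chain from an amide-type nitrogen. The measured steps at the same position, a step that the two limits leave unreadable from compound 1 to compound 3 and a step that the two limits leave unreadable from compound 2 to compound 3, cannot be read because of the limit of > 40000 nM in this assay, at which 3 of the 3 values shown sit. No readable step points in any direction, so compound 4 is expected to stay at that limit and a step that the limit leaves unreadable from compound 3 to compound 4 is expected to be no step beyond the scatter. For compound 4 the estimate is 60000 nM, within 30000 nM to 150000 nM.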

Compound 4, half-maximal cytotoxic concentration: > 40000 nM
Compound 4 gave a limit, no number; the forecaster's own chance of this, stated with the estimate: 85%; the middle value lies beyond the limit too.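

No step can be read between compound 4 and compound 1, compound 2 or compound 3, because all four give only a limit: the limit of > 40000 nM in this assay, at which 4 of the 4 values shown sit.

Going by these compounds, whether these four amide chain ends differ at all in toxicity to the cells stays open.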